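Compound 3: cyclopropylsulfonyl on the ring nitrogen

The source may hold more compounds than are shown below. What is called first, only, known or untested is meant among the compounds shown, and "the series" means these compounds.

Two compounds of the series have numbers in a functional assay on MDA-MB-231 cells (Homo sapiens) for inhibition, read by sulforhodamine B assay, tested at 10 uM; on this read-out lower numbers stand for less inhibition and higher numbers for more inhibition at the one concentration tested (going by the name of the read-out). Compound 1 `COC(=O)CC(=O)N1N=C(c2ccc(N3CCN(C)CC3)cc2)CC1c1ccc(N(C)C)cc1` gives -0.4%. For the measured compounds named here, compound 2 `CN1CCN(c2ccc(C3=NN(C(=O)/C=C/c4ccccc4)C(c4ccc(N(C)C)cc4)C3)cc2)CC1` gives 35.9%, the higher of the two, and the single measured step, a number 36.3 percentage points higher from compound 1 to compound 2 (beyond the scatter), arises from the exchange of the group on the carbonyl carbon. Compound 3 `CN1CCN(c2ccc(C3=NN(S(=O)(=O)C4CC4)C(c4ccc(N(C)C)cc4)C3)cc2)CC1` differs from compound 2 at the amine nitrogen in the ring: cyclopropylsulfonyl in place of (2-phenylethenyl)carbonyl on an amine nitrogen in a ring. Going by the values given here, no measured step covers a cyclopropylsulfonyl group here; the one step available shows only that exchanging the group on this nitrogen can move the read-out by a large amount, so a sizeable shift in this assay is possible in either direction. Compound 1, at -0.4%, is the only other reference. For compound 3 a downward step is therefore expected, a number 23.9 percentage points lower from compound 2 to compound 3 (beyond the scatter), with wide uncertainty. Compound 3 is estimated at 12%, in the range -10% to 35%.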

Compound 3, a percentage reported as inhibition, at one concentration (the size of the read-out at that concentration, not a potency): 3.7%
Compound 3: the middle estimate sits 8.3 percentage points above what was measured, within the range that was stated.
By their numbers in this assay, from the lowest: compounds 1 and 3 (each within the scatter of the next); then compound 2.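

In this assay, the exchange on the amine nitrogen in the ring gives a number 32.2 percentage points lower from compound 2 to compound 3 (beyond the scatter) on moving to cyclopropylsulfonyl, so among the three groups seen at this position, (2-phenylethenyl)carbonyl alone stands clear of the others. The second comparison, a number 4.1 percentage points higher from compound 1 to compound 3 (within the scatter), puts the sulfonyl-linked group level with the ((methoxycarbonyl)methyl)carbonyl group, which shows that a carbonyl link on this nitrogen does not by itself give the higher number. No measurement at hand offers an explanation for these differences.

Still open, on these data alone, is whether the higher number of compound 2 depends on the phenyl ring or on the double bond of its side chain, which a 3-phenylpropanoyl or a plain acetyl group would address. A phenylsulfonyl group would show whether a phenyl ring also lifts the number on the sulfonyl link.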